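Cytotoxicity of a nucleoside pair and an untested branched analogue

The source may hold more compounds than are shown below. What is called first, only, known or untested is meant among the compounds shown, and "the series" means these compounds.

Compound 1 `CC(C)C(Nc1nc(Cl)nc2c1ncn2[C@H]1[C@H](O)[C@H](O)[C@]2(CO)C[C@H]12)C(C)C` is one of two compounds examined in an ADME assay on Vero 76 cells (Chlorocebus sabaeus) for cytotoxicity, read by microscopy; a lower number here means that less compound is tolerated, a higher number that more compound is tolerated. Compound 1 gives > 100000 nM, which is a limit of the assay rather than a measured number. Compound 2 `NC(=O)c1ncn([C@H]2[C@H](O)[C@H](O)[C@]3(CO)C[C@H]23)n1` is the other compound examined, and in this assay compound 2 gives > 50000 nM, also a limit of the assay. Where compound 1 stands is thus described by the limit of > 100000 nM in this assay, at which 1 of the 2 values shown sits, and where compound 2 stands by the limit of > 50000 nM in this assay, at which 1 of the 2 values shown sits, so no step between measured compounds can be counted, and nothing is known about how either compound behaves once the tolerated concentration is exceeded.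

Compound 3 `CC(C)(C)[C@H](Nc1nc(Cl)nc2c1ncn2[C@H]1[C@H](O)[C@H](O)[C@]2(CO)C[C@H]12)C1CC1` has not yet been measured. It differs from compound 1 in one place: 1-cyclopropyl-2,2-dimethylpropyl in place of 1-isopropyl-2-methylpropyl on a nitrogen on an aromatic ring. The rest of compound 1 is unchanged. Because compound 1 gives only > 100000 nM, a limit, the expected step of a number no higher from compound 1 to compound 3 (the limit leaves the size open) is none beyond the scatter, and the outcome most expected for compound 3 is again a limit rather than a number. Compound 3 is therefore estimated at 100000 nM, with a range from 50000 nM to 200000 nM.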

Compound 3, half-maximal cytotoxic concentration: > 100000 nM
Compound 3 ended at the assay's limit; the forecaster's own chance of this, stated with the estimate: 85%; the middle value sits exactly at the limit.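

In this assay compound 3 gives > 100000 nM, which is a limit of the assay. For the compounds shown here, compound 1 also stands at a limit, so no step from compound 1 to compound 3 can be read. The compounds shown leave open at what concentration, if any, either compound becomes cytotoxic to these cells, and whether the changed group on the nitrogen shifts that concentration.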